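The source may hold more compounds than are shown below. What is called first, only, known or untested is meant among the compounds shown, and "the series" means these compounds.

Measured in a functional assay on NCI-H460 cells (Homo sapiens) for cytotoxicity, read by sulforhodamine B assay, with a stated time of 48 h; a higher number here means that more compound is needed for the effect, a lower number that less compound is needed:
compound 1, `CCN(CC)c1ccc(/C=C2/SC(N(c3ccccc3)c3ccccc3)=NC2=O)cc1`, gives > 100000 nM, a limit of the assay
compound 2, `CN1CCN(c2ccc(/C=C3/SC(N(c4ccccc4)c4ccccc4)=NC3=O)cc2)CC1`, gives > 100000 nM, a limit of the assay
compound 3, `CCN(CC)c1ccc(/C=C2/SC(N(C)c3ccccc3)=NC2=O)cc1`, gives 280 nM

Three compounds share a common core and are tested in this assay. Compound 1 reaches only a limit there. Compound 2 likewise reaches only a limit. Going by the values given here, compound 3 is the only one that gives a number, so it becomes the reference point for the set. Compound 3 differs from compound 1 by methyl in place of phenyl on a nitrogen on an aromatic ring, and that change brings an at least 350-fold lower number from compound 1 to compound 3 (2.55 log units; beyond the scatter). Compound 2 differs from compound 1 by 4-methylpiperazin-1-yl in place of diethylamino on an aromatic carbon, and the step there is a step that the two limits leave unreadable from compound 1 to compound 2, because the limit of > 100000 nM in this assay, at which 2 of the 3 values shown sit, hides both ends of it.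

Compound 4, `CN1CCN(c2ccc(/C=C3/SC(N(C)c4ccccc4)=NC3=O)cc2)CC1`, has not yet been tested. It differs from compound 3 by 4-methylpiperazin-1-yl in place of diethylamino on an aromatic carbon, the same change that separates compound 2 from compound 1 and made at the same place. Since that earlier step cannot be read, the size of the corresponding step from compound 3 is open, and the expectation rests only on compound 3 having a measurable value of 280 nM. It is expected that compound 4 will sit within a moderate distance of compound 3, giving a step of a 2.1-fold higher number from compound 3 to compound 4 (0.33 log units; beyond the scatter). Compound 4 is estimated at 600 nM, expected to fall between 150 nM and 3000 nM.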

Compound 4, half-maximal effective concentration: > 100000 nM
Compound 4 gave a limit, no number (the forecaster's own chance of this, stated with the estimate: 10%); middle value at least 160-fold (2.22 log units) from the limit.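

In this assay compound 4 gives > 100000 nM, which is a limit of the assay. Going by these compounds alone, on the core that carries methyl and phenyl on the nitrogen, 4-methylpiperazin-1-yl in place of diethylamino brings an at least 350-fold higher number from compound 3 to compound 4 (2.55 log units; beyond the scatter), so on this core the change removes the only measurable number in the set. This does not show that the change acts to the same extent on the core of compound 1, since neither the step from compound 1 to compound 2 nor the step from compound 2 to compound 4 can be read, because of this: the limit of > 100000 nM in this assay, at which 3 of the 4 values shown sit.

The compounds shown leave open whether a different cyclic amine on that aromatic carbon, such as morpholin-4-yl or piperidin-1-yl, or a smaller open-chain amine such as dimethylamino, would stay close to compound 3 at 280 nM or would also give no measurable number. They also leave open how this assay would respond to an ethyl or benzyl group in place of methyl on the nitrogen that carries the phenyl ring, with either diethylamino or 4-methylpiperazin-1-yl on the aromatic carbon.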